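A few compounds are considered here, and "the series" means these few. Any claim that something is new, unique, unknown or untested is made for them only; others in the source may bear on it.

Measured compounds: compound 1 `Cc1ccccc1NS(=O)(=O)c1ccc(N2CCNC2=O)cc1` gives 200 nM in a functional assay on HT-29 cells (Homo sapiens) for antiproliferative activity, read by sulforhodamine B assay, with a stated time of 48 h; a higher number here means a weaker inhibitor, a lower number a stronger inhibitor; compound 2 `O=C1NCCN1c1ccc(S(=O)(=O)Nc2ccc(F)c(F)c2)cc1` gives 350 nM; compound 3 `O=C1NCCN1c1ccc(S(=O)(=O)Nc2ccc(I)cc2)cc1` gives 650 nM.

Compound 3 carries the highest of the three numbers; its gap to compound 2 lies within the scatter, while the step of a 3.3-fold higher number from compound 1 to compound 3 (0.51 log units; beyond the scatter) is modest but beyond it. Compound 4 `COc1cccc(NS(=O)(=O)c2ccc(N3CCNC3=O)cc2)c1` differs from compound 3 by 3-methoxyphenyl in place of 4-iodophenyl on a sulfonamide nitrogen. Every measured step changes the same aryl group on the sulfonamide nitrogen: a 1.8-fold higher number from compound 1 to compound 2 (0.24 log units; within the scatter), a 3.3-fold higher number from compound 1 to compound 3 (0.51 log units; beyond the scatter) and a 1.9-fold higher number from compound 2 to compound 3 (0.27 log units; within the scatter). All stayed small. A comparable small shift is therefore expected in this assay, most likely toward a lower number, but not confidently beyond the scatter. For compound 4 the estimated step is a 1.6-fold lower number from compound 3 to compound 4 (0.21 log units; within the scatter), giving an expected value of 400 nM with a range from 150 nM to 1200 nM.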

Compound 4, half-maximal inhibitory concentration: 120 nM
Estimate against measurement, compound 4: 3.3-fold (0.52 log units) above, and the stated range ends above it.
By their numbers in this assay, from the lowest: compounds 4, 1, 2 and 3 (each within the scatter of the next, the first and the last beyond it).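

In this assay, the aryl group on the sulfonamide nitrogen produces a larger step than any seen earlier, with a 5.4-fold lower number from compound 3 to compound 4 (0.73 log units; beyond the scatter) and, also beyond the scatter, a 2.9-fold lower number from compound 2 to compound 4 (0.46 log units; beyond the scatter) in the same direction. Against the 2-methylphenyl compound, however, a 1.7-fold lower number from compound 1 to compound 4 (0.22 log units; within the scatter) leaves 3-methoxyphenyl and 2-methylphenyl indistinguishable in this read-out. No available evidence bears on what underlies these differences. Still open, going by these compounds, is how an amine or a carboxylic acid on this aryl ring, or a longer alkyl chain on the sulfonamide nitrogen, would compare.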